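A few compounds are considered here, and "the series" means these few. Any claim that something is new, unique, unknown or untested is made for them only; others in the source may bear on it.

The three measured compounds share one core, seen in compound 2 `Cc1ccc(S(=O)(=O)N[C@@H](CC(=O)NC(C)(C)C)C(=O)NCCNC(=O)c2ccccc2)cc1`. In an ADME assay on Karpas-1106P cells (Homo sapiens) for cytotoxicity (on this read-out higher numbers stand for an effect only at larger amounts of compound and lower numbers for an effect already at smaller amounts), compound 2 gives > 11100 nM, which is a limit of the assay and not a number. Compound 1 `Cc1ccc(S(=O)(=O)N[C@@H](CC(=O)NC(C)(C)C)C(=O)NCCNC(=O)c2cccc(O)c2)cc1` carries a hydroxy on an aromatic carbon where compound 2 carries hydrogen; in this assay compound 1 gives > 11100 nM, again a limit. Compound 3 `Cc1ccc(S(=O)(=O)N[C@@H](CC(=O)NC(C)(C)C)C(=O)NCCNC(=O)c2cccc(C(C)C)c2)cc1` carries an isopropyl in that place; in this assay compound 3 gives > 11100 nM, also a limit. The steps among these three cannot be sized: a step that the two limits leave unreadable from compound 1 to compound 2, a step that the two limits leave unreadable from compound 1 to compound 3 and a step that the two limits leave unreadable from compound 2 to compound 3 all remain unreadable because of the limit of > 11100 nM in this assay, at which 3 of the 3 values shown sit. Compound 4 `Cc1ccc(S(=O)(=O)N[C@@H](CC(=O)NC(C)(C)C)C(=O)NCCNC(=O)c2cccc(C#N)c2)cc1` has not yet been measured. It differs from compound 2 by cyano in place of hydrogen on an aromatic carbon. Going by the values given here, none of the measured steps speaks to this change, since every value so far is a limit rather than a number, and no direction can be read from them. With all neighbours sitting at the limit, the step that the limit leaves unreadable from compound 2 to compound 4 is expected to be none beyond the scatter, and the result will most likely be reported again only as a limit. For compound 4 the estimate in this assay is therefore 20000 nM, with a range from 8000 nM to 60000 nM.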

Compound 4, half-maximal effective concentration: > 11100 nM
Compound 4: a limit, no number; the forecaster's own chance of this, stated with the estimate: 85%; the middle value is on the limit's open side.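

None of the steps joining compound 4 to compound 1, compound 2 or compound 3 can be read in this assay, because the result for compound 4 is again a limit and not a number: the limit of > 11100 nM in this assay, at which 4 of the 4 values shown sit.

The compounds shown leave open how far these four differ in this assay, and which change to the shared core, if any, would yield a measurable number.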